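A few compounds are considered here, and "the series" means these few. Any claim that something is new, unique, unknown or untested is made for them only; others in the source may bear on it.

In a physicochemical assay for acid dissociation, compound 1 `CC#CCOc1noc2c1CNCC2` gives 7.6 and compound 2 `CC(C)Oc1noc2c1CNCC2` gives 7.5. Within the data shown here, these are the only two numbers so far, and compound 2 stands level with compound 1 once the usual scatter is allowed for. The measured step is a number 0.10 log units lower from compound 1 to compound 2 (within the scatter), and it comes from exchanging one group for another on an oxygen on an aromatic ring while the rest of the structure stays the same.

Compound 3 `C=C(Br)COc1noc2c1CNCC2` has not yet been measured. It carries a change at that same place, with 2-bromoprop-2-en-1-yl in place of isopropyl on an oxygen on an aromatic ring. Only the step shown above bears on this change, and it stayed within the scatter. Among the measured compounds shown here, no measured compound contains the incoming group, so that single step is thin evidence. A shift beyond the scatter is not expected in either direction. The expected result is no change at the digits printed from compound 2 to compound 3 (within the scatter). The estimate for compound 3 is 7.5, with the measurement expected to fall between 7.2 and 7.8.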

Compound 3, acid dissociation constant: 7.6
Compound 3: middle estimate off by 0.10 log units, on the low side; the measured number falls inside the stated range.
By their numbers in this assay, from the lowest: compounds 2, 1 and 3 (each within the scatter of the next).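

In this assay, the exchange of isopropyl for 2-bromoprop-2-en-1-yl reads as a number 0.10 log units higher from compound 2 to compound 3 (within the scatter), so bringing a bromine atom and a double bond outside aromatic rings to this oxygen on an aromatic ring leaves the number inside the usual scatter. The comparison with the but-2-yn-1-yl group reads as no change at the digits printed from compound 1 to compound 3 (within the scatter), which means that all three groups seen at this place give numbers that cannot be told apart, now including one that carries a heavy halogen atom. Nothing among the data offers an explanation for this sameness.

Isopropyl and 2-bromoprop-2-en-1-yl both count no hydrogen-bond donors, no hydrogen-bond acceptors and no net charge, so it remains open whether an amine, a carboxylic acid or a ring-bearing group on this oxygen would also stay within the scatter in this assay. Changes made elsewhere on the shared core lie outside these three compounds, so their effect on this number remains open as well.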